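The compounds below may be only part of what the source reports. "The series", "measured", "known", "first", "only" and "open" are said of these compounds alone.

Measured in an ADME assay on BJ cells (Homo sapiens) for cytotoxicity, with a stated time of 72 h; a higher number here means that more compound is needed for the effect, a lower number that less compound is needed; each entry is a limit, not a number:
- Compound 1 `CCc1ccc(-c2nc3c(c(C)nn3-c3ccccc3)c(-c3ccccc3Cl)c2C#N)cc1`: > 20000 nM (limit)
- Compound 2 `CCc1ccc(-c2nc3c(c(C)nn3-c3ccccc3)c(-c3ccccc3F)c2C#N)cc1`: > 20000 nM (limit)
- Compound 3 `CCc1ccc(-c2nc3c(c(C)nn3-c3ccccc3)c(-c3ccccc3OC)c2C#N)cc1`: > 20000 nM (limit)

Compound 3 stands at > 20000 nM, which is a limit of this assay. Compound 4 `CCc1ccc(-c2nc3c(c(C)nn3-c3ccccc3)c(-c3ccccc3)c2C#N)cc1` has hydrogen in place of methoxy on an aromatic carbon, ortho to a large group, turning 2-methoxyphenyl into phenyl (hydrogen in place of methoxy on an aromatic carbon).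

The measured steps that bear on this are a step that the two limits leave unreadable from compound 1 to compound 2, a step that the two limits leave unreadable from compound 1 to compound 3 and a step that the two limits leave unreadable from compound 2 to compound 3. None has a readable size, and compound 1, compound 2 and compound 3 all sit at the limit of > 20000 nM in this assay, at which 3 of the 3 values shown sit. With so little to go on, a step that the limit leaves unreadable from compound 3 to compound 4 is expected to be no step beyond the scatter. Compound 4 is estimated at 22000 nM, with an expected range from 12000 nM to 40000 nM. Another limit is the likeliest report.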

Compound 4, half-maximal effective concentration: > 20000 nM
Compound 4: no number, only a limit; the forecaster's own chance of this, stated with the estimate: 85%; the middle value does not contradict the limit.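

Compound 4 also gives only a limit, > 20000 nM, so its steps from compound 1, compound 2 and compound 3 cannot be read: the limit of > 20000 nM in this assay, at which 4 of the 4 values shown sit.

The compounds shown leave open whether swapping these groups changes the concentration needed for the effect at all.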